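The source may report more compounds than this note shows. Statements on the series, on what has been measured and on what is new or still open speak of the compounds shown alone.

Working notes on the series.

Compound 1 `CC(/C=N/Nc1ccc([N+](=O)[O-])cc1)=N\NC(=O)c1ccc(O)cc1` stands lowest of the two numbers in hand: in a functional assay on cells (Splenocyte, Mus musculus, strain BALB/c) for inhibition, read by scintillation counting and thymidine incorporation, with a stated time of 72 h (on this read-out higher numbers stand for weaker inhibition and lower numbers for stronger inhibition), compound 1 gives 1510 nM. Among the measured compounds shown here, the only measured neighbour is compound 2 `COc1cc(C(=O)N/N=C(C)/C=N/Nc2ccc([N+](=O)[O-])cc2)ccc1O`, which in this assay gives 5100 nM; the step of a 3.4-fold higher number from compound 1 to compound 2 (0.53 log units; beyond the scatter) is a methoxy in place of hydrogen on an aromatic carbon, a change on the same ring as the one now considered but not the same change.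

The next compound is compound 3 `CC(/C=N/Nc1ccc([N+](=O)[O-])cc1)=N\NC(=O)c1ccc(Cl)cc1`. It differs from compound 1 as chloro in place of hydroxy on an aromatic carbon.

For the measured compounds named here, no measured step covers hydroxy leaving and chloro entering; the one step on this ring, from compound 1 to compound 2, went to a higher number by a modest amount. Going by the values given here, with that as the only guide, a step of similar size is expected, direction uncertain but leaning towards a higher number, since the single change made so far on this ring gave a 3.4-fold higher number from compound 1 to compound 2 (0.53 log units; beyond the scatter). Compound 3 is therefore estimated at 2500 nM, within 800 nM to 8000 nM, an expected step of a 1.7-fold higher number from compound 1 to compound 3 (0.22 log units; within the scatter) in this assay.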

Compound 3, half-maximal inhibitory concentration: 4200 nM
Compound 3: the middle estimate sits 1.7-fold (0.23 log units) below what was measured, within the range that was stated.
By their numbers in this assay, from the lowest: compound 1; then compounds 3 and 2 (each within the scatter of the next).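

Chloro in place of hydroxy, para to a large group, gives in this assay a 2.8-fold higher number from compound 1 to compound 3 (0.44 log units; beyond the scatter), so this position responds to exchange of the hydroxy itself and not only to the methoxy change on the same ring. Both changes on this ring lead to a higher number beyond the scatter, leaving compound 1 lowest of the three, while the 4-chlorophenyl and 4-hydroxy-3-methoxyphenyl groups are not separated by this read-out, with a 1.2-fold lower number from compound 2 to compound 3 (0.08 log units; within the scatter). No measurement is available to explain the effect of this exchange.

The compounds shown leave open whether the higher number of compound 3 goes with the hydroxy leaving or with the chloro entering, since this single exchange does both at once. They also leave open how an amine or a carboxylic acid at the same place on the ring would read in this assay, and so whether any group there can match or go lower than compound 1.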